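Replacing the acetylsulfanyl chain of compound 3

The source may report more compounds than this note shows. Statements on the series, on what has been measured and on what is new or still open speak of the compounds shown alone.

In a functional assay on IGROV-1 cells (Homo sapiens) for inhibition, with a stated time of 72 h (on this read-out higher numbers stand for weaker inhibition and lower numbers for stronger inhibition), compound 1 `O=C(/C=C/c1ccc(-c2ccccc2)cc1)NO` gives 4000 nM and compound 2 `NNC(=O)/C=C/c1ccc(-c2ccccc2)cc1` gives 25100 nM in the same test. Compound 3 `CC(=O)SCC(=O)/C=C/c1ccc(-c2ccccc2)cc1` gives 18700 nM and belongs to the weaker pair, showing a 1.3-fold lower number from compound 2 to compound 3 (0.13 log units; within the scatter) and, on the other side, a 4.7-fold higher number from compound 1 to compound 3 (0.67 log units; beyond the scatter) as well.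

Compound 4 `N#CSC/C=C/c1ccc(-c2ccccc2)cc1` has (cyanosulfanyl)methyl in place of ((acetylsulfanyl)methyl)carbonyl on a double-bonded chain carbon bound to a double-bonded chain carbon. Among the measured compounds shown here, no measured step makes this exact swap. The nearest evidence is that replacing hydroxyamino was modest, with a 6.3-fold higher number from compound 1 to compound 2 (0.80 log units; beyond the scatter) as the other example, while the change between the two weaker compounds stayed within the scatter. No clear shift is therefore expected in this assay, and the expected step is a 1.2-fold lower number from compound 3 to compound 4 (0.10 log units; within the scatter) at most. Compound 4 is estimated at 15000 nM (range 5000 nM to 40000 nM).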

Compound 4, half-maximal inhibitory concentration: 58100 nM
The estimate for compound 4 lay 3.9-fold (0.59 log units) below the measured number, outside the stated range (above it).
By their numbers in this assay, from the lowest: compound 1; then compounds 3 and 2 (each within the scatter of the next); then compound 4.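

Unlike the step between the two weaker compounds, this change at the double-bonded chain carbon clearly moves the number in this assay, with a 3.1-fold higher number from compound 3 to compound 4 (0.49 log units; beyond the scatter) as the result. Among the compounds shown here, the (cyanosulfanyl)methyl group also trails aminocarbamoyl, giving a 2.3-fold higher number from compound 2 to compound 4 (0.36 log units; beyond the scatter) here, and hydroxycarbamoyl, giving a 15-fold higher number from compound 1 to compound 4 (1.16 log units; beyond the scatter) as the only large step. Each of the three groups it replaces carries a carbonyl, and all three give lower numbers.

No measurement shown gives a reason for these steps. From the compounds shown here alone, how a carboxylic acid or a simple amine would behave at this place remains open.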